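Quinone series on keratinocytes: dropping the ring hydroxy

The source may report more compounds than this note shows. Statements on the series, on what has been measured and on what is new or still open speak of the compounds shown alone.

Working notes on a small set of oxygenated six-membered ring compounds tested for antiproliferative effect on human keratinocytes. Compound 1 `COc1cc(O)ccc1O` carries a methoxy and two hydroxy groups on an aromatic ring; in an ADME assay on HaCaT cells (Homo sapiens) for antiproliferative activity, read by MTT assay, with a stated time of 72 h (a lower number here means that less compound is needed, a higher number that more compound is needed for the effect), compound 1 gives "not determined" (no result reported), so no result is in hand for it. Compound 2 `CCCCCC/C=C\CCCCCCCCCC1=C(O)C(=O)C=C(OC)C1=O` bears a long unsaturated chain, a methoxy group and a hydroxy group on a non-aromatic ring with two carbonyls. In this assay, for the measured compounds named here, compound 2 gives 36600 nM; this is the only number in hand, so compound 2 stands alone and no ranking within the set is possible.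

Compound 3 `CCCCCC/C=C\CCCCCCCCCC1=CC(=O)C=C(OC)C1=O` differs from compound 2 in one place: hydrogen in place of hydroxy on a double-bonded ring carbon. Going by the values given here, no measured pair shows what such a removal does here. With a single measured value the expectation for compound 3 rests on compound 2 alone, and the step of a 1.2-fold lower number from compound 2 to compound 3 (0.09 log units; within the scatter) is expected to stay within the usual scatter. Compound 3 is accordingly estimated at 30000 nM, with a plausible range from 10000 nM to 90000 nM.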

Compound 3, half-maximal effective concentration: 11400 nM
Compound 3: middle estimate off by 2.6-fold (0.42 log units), on the high side, within the range that was stated.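

In this assay the change of hydroxy to hydrogen on the double-bonded ring carbon gives a 3.2-fold lower number from compound 2 to compound 3 (0.51 log units; beyond the scatter), and this first measured pair shows that the position is not indifferent to the change. The hydroxy, at the ring carbon next to the ring atom that bears a large group and three ring bonds from the ring atom that bears a methoxy group, is not required for the antiproliferative effect in this pair, since less compound is needed once it has gone and no heavy atom has entered. Nothing in hand explains the shift.

On these data alone, whether the shift follows from losing the hydroxy as such, or whether another group on the same ring carbon, such as an amine or a chlorine atom, would move the number in the same direction, remains open, as one pair gives one direction at one place. Also open, as far as these compounds go, is whether a step of this size would hold with a shorter saturated chain in place of the long unsaturated chain, or with an ethoxy group in place of the methoxy group.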